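Fluoro to Ethoxycarbonyl: Expected Cytotoxicity of Compound 4

This account rests on a few compounds, and the source may have more. Where it says the series, first, only, none or still open, it means among the compounds named here.

Measured compounds:
- Compound 1, `O=C(O)CCc1cccc2c1B(O)OC2`: in an ADME assay on WI-38 cells (Homo sapiens) for cytotoxicity, read by MTT assay, with a stated time of 72 h (on this read-out lower numbers stand for stronger inhibition and higher numbers for weaker inhibition), compound 1 reaches only the assay limit, > 100000 nM.
- Compound 2, `O=C(CCc1cccc2c1B(O)OC2)Nc1ccc(F)cc1`: in this assay compound 2 gives 12000 nM.
- Compound 3, `CC(C)(C)OC(=O)NCc1ccc(NC(=O)CCc2cccc3c2B(O)OC3)cc1`: in this assay compound 3 gives 4800 nM.

Among the two numbers that are actual values rather than limits, compound 2 stands at the highest, meaning the weaker of the two inhibitors; its nearest neighbour is compound 3, and a 2.5-fold lower number from compound 2 to compound 3 (0.40 log units; beyond the scatter), a step that a larger group attached on an aromatic carbon brought a modestly lower number.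

Compound 4, `CCOC(=O)c1ccc(NC(=O)CCc2cccc3c2B(O)OC3)cc1`, has not yet been measured. It differs from compound 2 by ethoxycarbonyl in place of fluoro on an aromatic carbon. For the measured compounds named here, the only measured step that bears on this change is the one from compound 2 to compound 3, where a bulkier substituent replaced the fluoro and lowered the number beyond the scatter, though modestly. The ethoxycarbonyl is likewise larger than fluoro, so a small move towards a lower number is expected, but nothing that must exceed the scatter.

Compound 4 is therefore estimated at 8000 nM in this assay, within 3000 nM to 25000 nM, an expected step of a 1.5-fold lower number from compound 2 to compound 4 (0.18 log units; within the scatter).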

Compound 4, half-maximal inhibitory concentration: > 100000 nM
Compound 4: only a limit was reported (the forecaster's own chance of this, stated with the estimate: 5%); at least 12-fold (1.09 log units) between middle value and limit.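

For the compounds shown here, the position turns out to be far more sensitive than the earlier compounds suggested, and a larger group here does not by itself bring the number down. In this assay, putting ethoxycarbonyl in place of fluoro on this aromatic carbon gives an at least 8.3-fold higher number from compound 2 to compound 4 (0.92 log units; beyond the scatter), the opposite direction to a 2.5-fold lower number from compound 2 to compound 3 (0.40 log units; beyond the scatter), so on this read-out the change goes towards weaker inhibition, not stronger. Comparing the two larger groups directly gives an at least 20-fold higher number from compound 3 to compound 4 (1.31 log units; beyond the scatter), but compound 4 gives only a limit and not a number, so the full size of both new steps stays unknown: the limit of > 100000 nM in this assay, at which 2 of the 4 values shown sit.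

From the compounds shown here alone, with only fluoro, ((tert-butoxycarbonyl)amino)methyl and ethoxycarbonyl to compare at this carbon, it remains open whether a nitrile, a methoxy or a free aminomethyl would fall near compound 2, near compound 3 or at the limit. Also open, going by these compounds, is which part of the ethoxycarbonyl matters, which a methyl ketone or a simple amide at the same carbon could help separate.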